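Inverting One Stereocentre in Compound 1

This account rests on a few compounds, and the source may have more. Where it says the series, first, only, none or still open, it means among the compounds named here.

Measured in a functional assay on MCF7 cells (Homo sapiens) for cytotoxicity, read by MTT assay, with a stated time of 72 h; on this read-out lower numbers stand for stronger inhibition and higher numbers for weaker inhibition:
Compound 1 `O=C1c2c[n+]([O-])c3ccccc3c2C(=O)c2c1c1ccccc1n2Cc1cn([C@@H]2C[C@H](O)[C@@H](CO)O2)nn1`: 110 nM
Compound 2 `CN1CCN(CCCCn2c3c(c4ccccc42)C(=O)c2c[n+]([O-])c4ccccc4c2C3=O)CC1`: 100 nM
Compound 3 `CCCN1CCN(CCCCn2c3c(c4ccccc42)C(=O)c2c[n+]([O-])c4ccccc4c2C3=O)CC1`: 1280 nM

Compound 1 stands level with compound 2, their two values lying within the scatter of each other, while compound 3 alone has a clearly higher number. Compound 4 `O=C1c2c[n+]([O-])c3ccccc3c2C(=O)c2c1c1ccccc1n2Cc1cn([C@H]2C[C@H](O)[C@@H](CO)O2)nn1` is the next to be read. Its difference from compound 1 is this: the two compounds have the same atoms and bonds and differ only in configuration as drawn: 1 of 3 stereo elements differ; a stereocentre at a saturated ring carbon is drawn S in compound 1 and R in compound 4. A stereocentre at a saturated ring carbon is drawn S in compound 1 and R in compound 4.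

Among the measured compounds shown here, only one measured step is available, a 13-fold higher number from compound 2 to compound 3 (1.11 log units; beyond the scatter). It is large, but it concerns ethyl in place of hydrogen on a saturated chain carbon bound to an amine nitrogen in a ring, not a change of configuration. For the measured compounds named here, it shows that numbers in this small set can move widely, yet no measured pair tests a change like this one. In this assay, no step beyond the scatter is therefore expected, and no direction can be told, so the estimate stays close to compound 1 at 110 nM with a wide margin. The expected change is a 1.2-fold higher number from compound 1 to compound 4 (0.07 log units; within the scatter). For compound 4 the estimated value is 130 nM, with an expected range from 40 nM to 450 nM.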

Compound 4, half-maximal inhibitory concentration in the MCF7 assay: 530 nM
Compound 4: the middle estimate sits 4.1-fold (0.61 log units) below what was measured; measured number above the stated range.
By their numbers in the MCF7 assay, from the lowest: compounds 2 and 1 (each within the scatter of the next); then compound 4; then compound 3.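

Among the compounds shown here, in the MCF7 assay, the configuration at this saturated ring carbon alone carries a change beyond the scatter, a 4.8-fold higher number from compound 1 to compound 4 (0.68 log units; beyond the scatter), something the earlier compounds could not show, as no pair among them tested configuration: the fact that compounds 1 and 4 differ only in the configuration as drawn. In a physicochemical assay for solubility, read by HPLC, with a stated time of 24 h (on this read-out lower numbers stand for lower solubility and higher numbers for higher solubility), compound 1 gives > 5000 ug/mL, which is a limit of the assay and not a number. In the physicochemical assay compound 4 gives > 5000 ug/mL, again a limit, so the step between these two cannot be read.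

The compounds shown leave open whether inverting the other stereo elements of compound 1 would shift the number in the same way. They also leave open how an amine in place of the hydroxyl on the saturated ring would read at either configuration.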